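Two weak cytotoxic compounds and one untested analogue

This account rests on a few compounds, and the source may have more. Where it says the series, first, only, none or still open, it means among the compounds named here.

Measured compounds:
compound 1 `C#CCOc1ccc(/C=N/Cc2ccc(S(N)(=O)=O)cc2)cc1OC`: 136000 nM
compound 2 `O=Cc1cccc(OCc2cn(CCCOc3ccc4ccc(=O)oc4c3)nn2)c1`: 129000 nM

In a functional assay on HT-29 cells (Homo sapiens) for cytotoxicity, read by MTT assay, with a stated time of 24 h (on this read-out higher numbers stand for weaker inhibition and lower numbers for stronger inhibition), compound 1 gives 136000 nM, and in this assay compound 2 gives 129000 nM. Compound 2 carries the lower of the two numbers, but the gap to compound 1 lies within the scatter, so the two stand level.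

Compound 3 `COc1cc(C=O)ccc1OCc1cn(CCCOc2ccc3ccc(=O)oc3c2)nn1` differs from compound 2 by 4-formyl-2-methoxyphenyl in place of 3-formylphenyl on an oxygen on a saturated carbon. For the measured compounds named here, no measured pair here shows a change of this kind, so no step beyond the scatter is expected: the expected step is a 1.0-fold lower number from compound 2 to compound 3 (0.01 log units; within the scatter). Compound 3 is therefore estimated at 125000 nM, with a range from 50000 nM to 320000 nM.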

Compound 3, half-maximal inhibitory concentration: 65400 nM
The estimate for compound 3 lay 1.9-fold (0.28 log units) above the measured number, within the range that was stated.
By their numbers in this assay, from the lowest: compounds 3, 2 and 1 (each within the scatter of the next, the first and the last beyond it).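

In this assay, 4-formyl-2-methoxyphenyl in place of 3-formylphenyl on an oxygen on a saturated carbon gives a 2.0-fold lower number from compound 2 to compound 3 (0.30 log units; within the scatter). For the compounds shown here, this is the first pair that differs in one place, and it shows that this position tolerates the exchange without a step beyond the scatter. Nothing available here accounts for the size of this step.

The compounds shown leave open whether an amine or a carboxylic acid in place of the formyl group would give a step beyond the scatter. They also leave open what a longer chain at this position would do.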